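Bromo Substitution on a Quinoline Amine Series

The compounds below may be only part of what the source reports. "The series", "measured", "known", "first", "only" and "open" are said of these compounds alone.

Measured compounds:
compound 1, `CS(=O)(=O)C1(CNCc2cccc3cccnc23)CC1`, 479000000 nM
compound 2, `CN(C)S(=O)(=O)C1(CNCc2ccc(Cl)c3cccnc23)CC1`, 501000000 nM

Both measured compounds were tested in an assay on isolated protein for displacement of a labelled ligand from 5-hydroxytryptamine receptor 5A (Homo sapiens), read by radioligand binding, with a stated time of 2 h; a lower number here means a stronger inhibitor, a higher number a weaker inhibitor. Compound 1 gives 479000000 nM, and compound 2 gives 501000000 nM. Compound 1 has the lower of the two numbers, yet compound 2 lies so close that the two values fall within the scatter of repeated measurements; neither can be called stronger than the other. Both numbers are very high, so both compounds are weak inhibitors in this assay.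

The unmeasured compound 3, `CS(=O)(=O)C1(CNCc2ccc(Br)c3cccnc23)CC1`, is derived from compound 1 by one change: bromo in place of hydrogen on an aromatic carbon. Within the data shown here, with no measured pair showing this exact change, no step size can be read from the data. The expectation is therefore for no shift beyond the scatter, a step of a 1.1-fold lower number from compound 1 to compound 3 (0.03 log units; within the scatter). Compound 3 is estimated to give 450000000 nM in this assay, within a range from 150000000 nM to 1300000000 nM.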

Compound 3, half-maximal inhibitory concentration: 513000000 nM
Compound 3: middle estimate off by 1.1-fold (0.06 log units), on the low side; low and high end bracket the measured number.
By their numbers in this assay, from the lowest: compounds 1, 2 and 3 (each within the scatter of the next).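

In this assay, bromo in place of hydrogen on an aromatic carbon, para to a large group, gives a 1.1-fold higher number from compound 1 to compound 3 (0.03 log units; within the scatter). Among these compounds, this is the first pair of compounds here that differ in one place, and it shows that this single change does not move the number beyond the usual scatter, with compound 3 remaining a weak inhibitor like compound 1. Nothing measured here gives a reason for this result.

From the compounds shown here alone, whether a different kind of group on this same aromatic carbon, such as an amine or a carboxylic acid, would shift the number beyond the scatter remains open. Going by these compounds, it is also open whether a change elsewhere on the shared core, such as a longer chain, would turn these weak inhibitors into stronger ones.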